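The source may report more compounds than this note shows. Statements on the series, on what has been measured and on what is new or still open speak of the compounds shown alone.

Compound 1 `COc1ccc(C(=O)c2sc(NC(C)C)c(C#N)c2N)cc1` carries a methoxyphenyl on the carbonyl, and in an assay for inhibition of Maternal embryonic leucine zipper kinase (Homo sapiens), read by ADP-Glo, with a stated time of 0.5 h (on this read-out higher numbers stand for weaker inhibition and lower numbers for stronger inhibition), compound 1 gives 4130 nM. Compound 2 `CC(C)Nc1sc(C(=O)c2cccc(C#N)c2)c(N)c1C#N` is reported only as a limit of the read-out, and in this assay compound 2 gives > 5000 nM. Compound 3 `CC(C)Nc1sc(C(=O)c2ccncc2)c(N)c1C#N` is likewise reported only as a limit, and in this assay compound 3 gives > 5000 nM. Compound 3 thus stands at the limit of > 5000 nM in this assay, at which 2 of the 3 values shown sit, with no number of its own. Compound 4 `CC(C)Nc1sc(C(=O)c2ccc(I)s2)c(N)c1C#N` differs from compound 3 by 5-iodothiophen-2-yl in place of pyridin-4-yl on a carbonyl carbon. Among the compounds with values here, no measured step of this kind is available, so only a cautious expectation can be formed: the step from compound 3 to compound 4 is expected to be an at least 1.6-fold lower number from compound 3 to compound 4 (0.22 log units; that floor lies within the scatter), a gain barely beyond the scatter. Compound 4 is accordingly expected to give 3000 nM, within a range from 800 nM to 12000 nM.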

Compound 4, half-maximal inhibitory concentration: 112 nM
The estimate for compound 4 lay 27-fold (1.43 log units) above the measured number; measured number outside the range, below it.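

In this assay, within the data shown here, the group on the carbonyl carbon proves able to move the read-out strongly: 5-iodothiophen-2-yl in place of pyridin-4-yl gives an at least 44-fold lower number from compound 3 to compound 4 (1.64 log units; beyond the scatter), whereas the earlier compounds offered no measured step at this position. The true size of this step stays unknown, as compound 3 is held only at a limit: the limit of > 5000 nM in this assay, at which 2 of the 4 values shown sit.

The compounds shown do not separate the contribution of the iodine from that of the thiophene ring. On these data alone, whether a bromine or a methyl group in place of the iodine would keep the gain remains open.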